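This account rests on a few compounds, and the source may have more. Where it says the series, first, only, none or still open, it means among the compounds named here.

Compound 1 `CS(=O)(=O)c1ccc(-c2oc3ccccc3c(=O)c2-c2ccc(F)cc2)cc1` carries a 4-fluorophenyl group on the shared core. In an assay on isolated protein for inhibition of prostaglandin G/H synthase 1 (Mus musculus), tested at 10 ug/mL (a lower number here means less inhibition, a higher number more inhibition at the concentration tested (going by the name of the read-out)), compound 1 gives < 8%, which is a limit of the assay and not a measured number. Compound 2 `CSc1ccc(-c2c(-c3ccc(S(N)(=O)=O)cc3)oc3ccccc3c2=O)cc1` differs from compound 1 in more than one place, so no single change can be weighed between them; in this assay compound 2 gives 90%. Within the data shown here, no pair of measured compounds differs in one place, and the only fixed point for the series is the limit of < 8% in this assay, at which 1 of the 2 values shown sits. Compound 3 `CS(=O)(=O)c1ccc(-c2oc3ccccc3c(=O)c2-c2cccc(Cl)c2)cc1` is not yet measured. (3-chlorophenyl in place of 4-fluorophenyl on an aromatic carbon). For this change only a step of a number at least 4 percentage points higher from compound 1 to compound 3 (that floor lies within the scatter) is expected, nothing beyond the scatter in either direction. Compound 3 is therefore estimated at 12%, with a range from 0% to 35%, and with a fair chance that the assay again reports only a limit.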

Compound 3, a percentage reported as inhibition, at one concentration (the size of the read-out at that concentration, not a potency): < 5%
Compound 3 ended at the assay's limit (the forecaster's own chance of this, stated with the estimate: 45%); at least 7 percentage points between middle value and limit.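

Compound 1 and compound 3 are both reported only as limits in this assay, so the step between them, 3-chlorophenyl in place of 4-fluorophenyl, cannot be read. The compounds shown leave open what effect, if any, this change has in this assay.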